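This account rests on a few compounds, and the source may have more. Where it says the series, first, only, none or still open, it means among the compounds named here.

Compounds measured:
- compound 1 `O=C(CCC1CCCC1)NC[C@H]1NC[C@H](O)[C@@H](O)[C@H]1O`: 37%
- compound 2 `NC[C@@H]1NC[C@H](O)[C@H](O)[C@H]1O`: 13%
- compound 3 `COc1ccc(Br)cc1/C=C/C(=O)NC[C@H]1NC[C@H](O)[C@@H](O)[C@H]1O`: 47%

In an assay on isolated protein for inhibition of alpha-galactosidase (Coffea arabica), read by spectrophotometry, tested at 100 uM (a higher number here means more inhibition at the concentration tested (going by the name of the read-out), a lower number less inhibition), compound 2 gives 13%, the lowest of the three numbers. Compound 1 gives 37% and compound 3 gives 47% in this assay; both values stand beyond the scatter above that of compound 2.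

Compound 4 `NC[C@H]1NC[C@H](O)[C@H](O)[C@H]1O` has not yet been measured. The difference between compound 2 and compound 4 is the two compounds have the same atoms and bonds and differ only in configuration as drawn: 1 of 4 stereo elements differ; a stereocentre at a saturated ring carbon is drawn S in compound 2 and R in compound 4. Among the measured compounds shown here, no pair of the measured compounds differs in one place, so nothing shows how large a step this change brings. The expected step in this assay from compound 2 to compound 4 is a number 5 percentage points higher from compound 2 to compound 4 (within the scatter), small and within the scatter. Compound 4 is estimated at 18%, with a range from 5% to 40%.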

Compound 4, a percentage reported as inhibition, at one concentration (the size of the read-out at that concentration, not a potency): "not active" (no number reported)
The entry for compound 4 holds no number; no gap can be computed for the estimate.
By their numbers in this assay, from the lowest: compound 2; then compounds 1 and 3 (each within the scatter of the next).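

Among the compounds shown here, compound 4 is entered as not active in this assay, with no number, and no step from compound 2 to compound 4 can be read. The compounds shown leave open how far this single change of configuration shifts inhibition.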